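The source may report more compounds than this note shows. Statements on the series, on what has been measured and on what is new or still open speak of the compounds shown alone.

Working notes on the series, on the ring-nitrogen substituent.

Compound 1 `Cc1nc(N2CCN(C3CCOCC3)CC2)nc2ccc(NC(=O)COc3ccc(Cl)cc3)cc12` has the shared core with an oxan-4-yl group on the ring nitrogen and a chloro group on the aryl ether. In a functional assay on CHO-K1 cells for antagonist activity at melanin-concentrating hormone receptor 1 (Homo sapiens), read by inositol phosphate accumulation (a higher number here means a weaker inhibitor, a lower number a stronger inhibitor), compound 1 gives 115 nM, the highest of the two numbers in hand. Compound 3 `Cc1nc(N2CCN(C3CCOCC3)CC2)nc2ccc(NC(=O)COc3ccc(OC(F)(F)F)cc3)cc12` gives 31 nM in this assay; the step of a 3.7-fold lower number from compound 1 to compound 3 (0.57 log units; beyond the scatter) is modest but beyond the scatter. Compound 2 `Cc1nc(N2CCC(O)CC2)nc2ccc(NC(=O)C(C)(C)Oc3ccc(Cl)cc3)cc12` differs from compound 1 in two places, and in this assay compound 2 reaches only the limit > 10000 nM, a limit of the assay and not a number (the limit of > 10000 nM in this assay, at which 1 of the 3 values shown sits).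

Compound 4 `Cc1nc(N2CCN(C)CC2)nc2ccc(NC(=O)COc3ccc(Cl)cc3)cc12` carries the change (methyl in place of oxan-4-yl on an amine nitrogen in a ring). Among the compounds with values here, no measured step touches this position: the one measured step lies on the aromatic carbon, and compound 2 changes two places at once. With nothing to anchor a direction, the number for compound 4 is expected near that of compound 1, a step of a 1.3-fold higher number from compound 1 to compound 4 (0.12 log units; within the scatter) inside the scatter. The estimate for compound 4 in this assay is 150 nM, between 40 nM and 600 nM.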

Compound 4, half-maximal inhibitory concentration: 3800 nM
For compound 4 the middle estimate is 25-fold (1.40 log units) below the measured one; measured number above the stated range.
By their numbers in this assay, from the lowest: compound 3; then compound 1; then compound 4. At a limit, above all of these: compound 2.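

In this assay, this position responds strongly to its substituent: methyl in place of oxan-4-yl on the amine nitrogen gives a 33-fold higher number from compound 1 to compound 4 (1.52 log units; beyond the scatter). Within the data shown here, this is the first single change measured at this position, and it is larger than the one step on the aromatic carbon, a 3.7-fold lower number from compound 1 to compound 3 (0.57 log units; beyond the scatter). Nothing in hand accounts for the size of the step.

The change removes the ring and its oxygen together, so the step cannot say which of them matters; a cyclohexyl group, which keeps the ring without the oxygen, or a methoxyethyl chain, which keeps the oxygen without the ring, would separate the two. Going by these compounds, it also remains open whether the step carries over to the trifluoromethoxy aryl ether of compound 3.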